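Series notes: trifluoromethyl to trifluoromethoxy on the phenyl ring

This account rests on a few compounds, and the source may have more. Where it says the series, first, only, none or still open, it means among the compounds named here.

Compound 1 `COc1cc2c(Oc3ccc(NC(=O)c4nn(-c5ccccc5)c(=O)cc4C)cc3F)ccnc2cc1OCCCN1CCCC1` is the reference point of this pair. In a functional assay on NCI-H460 cells (Homo sapiens) for inhibition, read by MTT assay, with a stated time of 72 h (on this read-out higher numbers stand for weaker inhibition and lower numbers for stronger inhibition), compound 1 gives 460 nM. Compound 2 `COc1cc2c(Oc3ccc(NC(=O)c4nn(-c5ccccc5C(F)(F)F)c(=O)cc4C)cc3F)ccnc2cc1OCCCN1CCCC1` carries a trifluoromethyl on the phenyl ring in place of a hydrogen, and in this assay compound 2 gives 210 nM. Within the data shown here, the step of a 2.2-fold lower number from compound 1 to compound 2 (0.34 log units; beyond the scatter) is the only measured step in the set, and it places compound 2 at the lower of the two numbers, with compound 1 beyond the scatter above it.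

Compound 3 `COc1cc2c(Oc3ccc(NC(=O)c4nn(-c5ccccc5OC(F)(F)F)c(=O)cc4C)cc3F)ccnc2cc1OCCCN1CCCC1` is not yet measured. It differs from compound 2 by trifluoromethoxy in place of trifluoromethyl on an aromatic carbon. Among the measured compounds shown here, the single measured step, a 2.2-fold lower number from compound 1 to compound 2 (0.34 log units; beyond the scatter), touches the same ring position but a different exchange, so it gives only a loose guide; it was modest, and the further exchange of a trifluoromethyl for a trifluoromethoxy is expected to move the number less than that, if at all. The expected step of a 1.2-fold higher number from compound 2 to compound 3 (0.09 log units; within the scatter) is therefore within the scatter. Compound 3 is expected to give 260 nM in this assay, with a range from 110 nM to 650 nM.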

Compound 3, half-maximal inhibitory concentration: 210 nM
Beside the measured number, compound 3's estimate is 1.2-fold (0.09 log units) above it, and the stated range covers the measured number.
By their numbers in this assay, from the lowest: compounds 2 and 3 (each within the scatter of the next); then compound 1.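

In this assay, the exchange of trifluoromethyl for trifluoromethoxy on the phenyl ring reads as no change at the digits printed from compound 2 to compound 3 (within the scatter), so adding the oxygen and its hydrogen-bond acceptor leaves the read-out unmoved at this position. Measured against the unsubstituted phenyl, trifluoromethoxy gives a 2.2-fold lower number from compound 1 to compound 3 (0.34 log units; beyond the scatter), which matches the modest step seen with trifluoromethyl, so that step is not confined to a single group. No measurement beyond these cell numbers is available to account for the match between the two groups.

Both substituents that give this step are fluorinated, so a methyl, a methoxy, a chlorine or an amine on the same aromatic carbon would be needed to show whether the fluorine atoms matter or whether any group there gives the same modest step. It also remains open whether the step depends on this position at all, since the two groups are shown on only one carbon of the phenyl ring, and a trifluoromethoxy on another carbon of that ring would test this directly.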